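The compounds below may be only part of what the source reports. "The series", "measured", "known", "first", "only" and "open" are said of these compounds alone.

Three compounds share one core. Compound 1 `COc1ccc(-c2ccc(C)n2-c2ccc(-c3nc4ccccc4s3)cc2)cc1` gives 3260 nM in a functional assay on MCF7 cells (Homo sapiens) for cytotoxicity, read by MTT assay, with a stated time of 72 h (on this read-out higher numbers stand for weaker inhibition and lower numbers for stronger inhibition), compound 2 `Cc1ccc(-c2ccc(C)n2-c2ccc(-c3nc4ccc(F)cc4s3)cc2)cc1` gives 2970 nM, and compound 3 `Cc1ccc(-c2ccc(F)cc2)n1-c1ccc(-c2nc3ccc(F)cc3s2)cc1` gives 2800 nM. Compound 3 has the lowest of these three numbers, but the step of a 1.1-fold lower number from compound 2 to compound 3 (0.03 log units; within the scatter) is within the scatter, and the values of compound 1 and compound 3 likewise lie close together. Compound 4 `COc1ccc(-c2ccc(C)n2-c2ccc(-c3nc4ccc(F)cc4s3)cc2)cc1` is the next compound: methoxy in place of fluoro on an aromatic carbon. Within the data shown here, the only single measured step, the one from compound 2 to compound 3, swapped groups at this same place and left the number essentially unchanged, so the change to compound 4 is expected to give no step beyond the scatter, a 1.1-fold higher number from compound 3 to compound 4 (0.03 log units; within the scatter). Compound 4 is therefore estimated at 3000 nM, with a range from 1500 nM to 6500 nM.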

Compound 4, half-maximal inhibitory concentration: 2550 nM
Compound 4: middle estimate off by 1.2-fold (0.07 log units), on the high side; measured number inside the range.
By their numbers in this assay, from the lowest: compounds 4, 3, 2 and 1 (each within the scatter of the next).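

In this assay, three groups at this position now give numbers that cannot be told apart: fluoro to methoxy gives a 1.1-fold lower number from compound 3 to compound 4 (0.04 log units; within the scatter) and methyl to methoxy gives a 1.2-fold lower number from compound 2 to compound 4 (0.07 log units; within the scatter) on the same aromatic carbon. A second place on the shared core also comes into view, where fluoro in place of hydrogen gives a 1.3-fold lower number from compound 1 to compound 4 (0.11 log units; within the scatter) and so likewise shows no real change. No supporting measurement accounts for this flat picture. As far as these compounds go, whether an amine or a carboxylic acid at the first position would move the number beyond the scatter stays open.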